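The source may report more compounds than this note shows. Statements on the series, on what has been measured and on what is new or still open speak of the compounds shown alone.

Compound 1 `CCCc1ccc(-c2ccc3ncc(C(=O)OCC)cc3c2)cc1` and compound 2 `CCCCc1ccc(-c2ccc3ncc(C(=O)OCC)cc3c2)cc1` share a core on which an alkyl chain sits on an outer six-membered aromatic ring of carbon only. In a functional assay on RD cells (Homo sapiens) for inhibition, read by luminescence and ATP content, with a stated time of 72 h (on this read-out higher numbers stand for lower toxicity in this test and lower numbers for higher toxicity in this test), compound 1 gives > 7400 nM, which is a limit of the assay and not a number. In this assay compound 2 gives > 7400 nM, again a limit rather than a number. The step that the two limits leave unreadable from compound 1 to compound 2 therefore cannot be read in size or direction, since both of its ends rest at the limit of > 7400 nM in this assay, at which 2 of the 2 values shown sit. Where compound 2 stands in this assay is thus known only as a limit, and the one further value shown is a limit too.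

Compound 3 `CCOC(=O)c1cnc2ccc(-c3ccccc3)cc2c1` differs from compound 2 by hydrogen in place of butyl on an aromatic carbon. Among the measured compounds shown here, the only measured step that bears on this change is the one from compound 1 to compound 2, and its size is unreadable because both values sit at the limit of > 7400 nM in this assay, at which 2 of the 2 values shown sit. With nothing beyond the scatter shown between the two measured compounds, compound 3 is expected to come out in this assay at 10000 nM, within 4000 nM to 40000 nM, most likely again as a limit. The expected step is estimated as a step that the limit leaves unreadable from compound 2 to compound 3, no change beyond the scatter.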

Compound 3, half-maximal cytotoxic concentration: > 7400 nM
Compound 3 was reported as a limit; the forecaster's own chance of this, stated with the estimate: 80%; the middle value does not contradict the limit.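

Compound 3 also gives a limit of the assay and not a number in this assay, so neither step to compound 3, from compound 1 or from compound 2, can be read in size or direction: the limit of > 7400 nM in this assay, at which 3 of the 3 values shown sit.

The compounds shown leave open whether hydrogen, propyl or butyl on that aromatic carbon makes any difference in this assay.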